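From Compound 3 to Compound 4: Testing a Flat Series

A few compounds are considered here, and "the series" means these few. Any claim that something is new, unique, unknown or untested is made for them only; others in the source may bear on it.

In a functional assay on PC-3 cells (Homo sapiens) for antiproliferative activity, read by sulforhodamine B assay, with a stated time of 72 h (on this read-out higher numbers stand for weaker inhibition and lower numbers for stronger inhibition), compound 1 `COc1ncc(-c2ccc3ncc(NCc4ccc(C(F)(F)F)cc4)c(OC)c3c2)cc1NS(=O)(=O)c1ccc(F)cc1F` gives 2880 nM, compound 2 `COc1ccc(CNc2cnc3ccc(-c4cnc(OC)c(NS(=O)(=O)c5ccc(F)cc5F)c4)cc3c2OC)cc1` gives 4520 nM and compound 3 `COc1ncc(-c2ccc3ncc(NCC4CCN(C(C)=O)CC4)c(OC)c3c2)cc1NS(=O)(=O)c1ccc(F)cc1F` gives 2570 nM, which places compound 3 within the scatter of both others. Compound 4 `COc1ncc(-c2ccc3ncc(NC(C)=O)c(OC)c3c2)cc1NS(=O)(=O)c1ccc(F)cc1F` differs from compound 3 in one place: acetyl in place of (1-acetylpiperidin-4-yl)methyl on a nitrogen on an aromatic ring. Two measured changes to this side chain bear on it, a 1.1-fold lower number from compound 1 to compound 3 (0.05 log units; within the scatter) and a 1.8-fold lower number from compound 2 to compound 3 (0.25 log units; within the scatter), both within the scatter. Neither removes the whole chain, so this evidence is indirect, and no shift beyond the scatter is expected. The expected step is a 1.2-fold higher number from compound 3 to compound 4 (0.07 log units; within the scatter). For compound 4 the estimate is 3000 nM, with an expected range of 1000 nM to 9000 nM.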

Compound 4, half-maximal inhibitory concentration: 1240 nM
Beside the measured number, compound 4's estimate is 2.4-fold (0.38 log units) above it, and the stated range covers the measured number.
By their numbers in this assay, from the lowest: compound 4; then compounds 3, 1 and 2 (each within the scatter of the next).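

In this assay, going by these compounds alone, replacing the larger groups on this nitrogen with acetyl gives the first steps beyond the scatter, a 2.1-fold lower number from compound 3 to compound 4 (0.32 log units; beyond the scatter) and a 2.3-fold lower number from compound 1 to compound 4 (0.37 log units; beyond the scatter) and also a 3.6-fold lower number from compound 2 to compound 4 (0.56 log units; beyond the scatter), all modest and all in the same direction. The aromatic, trifluoromethyl-bearing and acetylpiperidine side chains stay within the scatter of one another, so only the change to acetamido separates a compound from the rest. No evidence here accounts for this shift. That change shortens the group and also places a carbonyl directly on the nitrogen, and the compounds shown do not separate these two differences. On these data alone, whether a free amine, an ethyl group or a longer acyl chain such as propanoyl would give a similar number remains open.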